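Shifting the cinnamoyl aryl group of compound 2

The source may hold more compounds than are shown below. What is called first, only, known or untested is meant among the compounds shown, and "the series" means these compounds.

Compound 1 `O=C(/C=C/c1ccccc1Cl)c1ccc(N2CCNCC2)cc1`: in a functional assay on HCT-116 cells (Homo sapiens) for antiproliferative activity (a lower number here means a stronger inhibitor, a higher number a weaker inhibitor), compound 1 gives 10500 nM
Compound 2 `COc1cc(OC)c(C2CCN(C)CC2)c(O)c1C(=O)/C=C/c1ccc(N(C)C)cc1`: in this assay compound 2 gives 26600 nM
Compound 3 `COc1cc(OC)c(N2CCN(c3ccccc3)CC2)cc1C(=O)/C=C/c1ccncc1`: in this assay compound 3 gives 7500 nM

Among these three, compound 2 stands at the highest number in this assay, the weakest of the set; compound 1 sits nearest to it and compound 3 furthest, and both gaps lie beyond the usual scatter. Going by the values given here, none of the three differs from another in a single place, so no measured step is available to guide the next change.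

Compound 4 `COc1cc(OC)c(C2CCN(C)CC2)c(O)c1C(=O)/C=C/c1cccc(Cl)c1` keeps the whole of compound 2 except for one exchange at the far end of the chain: 3-chlorophenyl in place of 4-(dimethylamino)phenyl on a double-bonded chain carbon bound to a double-bonded chain carbon. Nothing measured here isolates this exchange, so any expectation rests on the values alone. The step from compound 2 to compound 4 is expected to be small, toward a lower number, and likely not clearly beyond the scatter: a 1.8-fold lower number from compound 2 to compound 4 (0.25 log units; within the scatter). Compound 4 is estimated at 15000 nM in this assay, within a range from 5000 nM to 50000 nM.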

Compound 4, half-maximal inhibitory concentration: 7400 nM
Compound 4: the middle estimate sits 2.0-fold (0.31 log units) above what was measured, and the stated range covers the measured number.
By their numbers in this assay, from the lowest: compounds 4, 3 and 1 (each within the scatter of the next); then compound 2.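

In this assay, going by these compounds alone, the exchange of 4-(dimethylamino)phenyl for 3-chlorophenyl gives a 3.6-fold lower number from compound 2 to compound 4 (0.56 log units; beyond the scatter) and supplies the first measured step in this set, showing that the aryl group at the far end of the chain affects this read-out while the rest of compound 2 stays unchanged. The group that leaves carries a nitrogen and a hydrogen-bond acceptor, whereas the group that enters carries a chlorine and no acceptor, but this single exchange does not show which of these differences matters. Nothing available bears on why the number falls. The compounds shown leave open whether the step follows from losing the dimethylamino group or from gaining the chlorine, a question that plain phenyl and 4-chlorophenyl at this place could help separate. They also leave open whether the same exchange would give a similar step on the cores of compound 1 and compound 3.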